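A few compounds are considered here, and "the series" means these few. Any claim that something is new, unique, unknown or untested is made for them only; others in the source may bear on it.

Measured compounds in a functional assay on cardiac atrium for agonist activity at histamine H2 receptor (Cavia porcellus); on this read-out lower numbers stand for smaller maximal responses and higher numbers for larger maximal responses:

compound 1 `N=C(NCCCc1c[nH]cn1)NC(=O)CC(c1ccccc1)c1ccc(F)c(F)c1`: 81%
compound 2 `N=C(NCCCc1c[nH]cn1)NC(=O)CC(c1ccccc1)c1ccccn1`: 97%
compound 3 `N=C(NCCCc1c[nH]cn1)NC(=O)CC(c1ccccc1)c1nccs1`: 100%

Compound 3 gives the highest of the three numbers in this assay. Compound 2 lies close by, the gap of a number 3 percentage points higher from compound 2 to compound 3 (within the scatter) being within the scatter, so no order between compound 2 and compound 3 is claimed. Compound 1 stands furthest off, with a number 19 percentage points higher from compound 1 to compound 3 (beyond the scatter) and, for the other comparison, a number 16 percentage points higher from compound 1 to compound 2 (beyond the scatter).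

Compound 4 `N=C(NCCCc1c[nH]cn1)NC(=O)CC(c1ccc(F)c(F)c1)c1nccs1` differs from compound 3 in one place: 3,4-difluorophenyl in place of phenyl on a saturated chain carbon bound to an aromatic carbon and a saturated chain carbon. Among the measured compounds shown here, no measured step swaps phenyl for 3,4-difluorophenyl on this carbon directly. For the measured compounds named here, what bears on it is that the only compound carrying 3,4-difluorophenyl, compound 1, sits lowest, and both steps that remove it, a number 16 percentage points higher from compound 1 to compound 2 (beyond the scatter) and a number 19 percentage points higher from compound 1 to compound 3 (beyond the scatter), run upward by a modest amount. Introducing the same group into compound 3 is therefore expected to lower the maximal response by a modest amount, a number 12 percentage points lower from compound 3 to compound 4 (beyond the scatter), though with three compounds this is a loose expectation.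

Compound 4 is estimated at 88% in this assay, within 72% to 102%.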

Compound 4, largest response reached (Emax), in percent of the reference or control that the assay uses: 90%
Compound 4: the middle estimate sits 2 percentage points below what was measured; low and high end bracket the measured number.
By their numbers in this assay, from the lowest: compounds 1, 4, 2 and 3 (each within the scatter of the next, the first and the last beyond it).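

In this assay, the direct swap to 3,4-difluorophenyl in place of phenyl on this carbon, with 1,3-thiazol-2-yl kept, gives a number 10 percentage points lower from compound 3 to compound 4 (within the scatter), so the earlier reading of this group as lowering the response is not confirmed as a change beyond the scatter. With 3,4-difluorophenyl kept, 1,3-thiazol-2-yl in place of phenyl gives a number 9 percentage points higher from compound 1 to compound 4 (within the scatter), so the wider gap a number 19 percentage points higher from compound 1 to compound 3 (beyond the scatter) divides into two steps, neither of which can be told from the scatter on its own. Nothing available gives a reason for these small steps.

Still open, going by these compounds, is whether a single fluorine, a methoxy group or an amine on the phenyl ring would shift the response beyond the scatter. Also open, on these data alone, is how pyridin-2-yl behaves when paired with 3,4-difluorophenyl on this carbon.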